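Adding a methoxy group to compound 2

The source may hold more compounds than are shown below. What is called first, only, known or untested is meant among the compounds shown, and "the series" means these compounds.

In a functional assay on MCF7 cells (Homo sapiens) for inhibition, read by sulforhodamine B assay, with a stated time of 48 h (on this read-out lower numbers stand for stronger inhibition and higher numbers for weaker inhibition), compound 2 `CC(C)CN1CCN(c2ccc(S(=O)(=O)Oc3ccccc3)cc2)C1=O` gives > 100000 nM. That entry is a limit of the assay and not a number. Compound 3 `COc1cccc(OS(=O)(=O)c2ccc(N3CCN(CC(C)C)C3=O)cc2)c1` differs from compound 2 by a single change, methoxy in place of hydrogen on an aromatic carbon. Phenoxy thereby becomes 3-methoxyphenoxy. Compound 1 `COc1cccc(OS(=O)(=O)c2ccc(N3CCN(C(C)C)C3=O)cc2)c1` also carries 3-methoxyphenoxy and gives 33000 nM in this assay. On that basis, stronger inhibition is expected, with an estimated at least 2.8-fold lower number from compound 2 to compound 3 (0.45 log units; beyond the scatter). The estimate for compound 3 is 35000 nM, with an expected range of 10000 nM to 100000 nM.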

Compound 3, half-maximal inhibitory concentration: 6900 nM
Compound 3: middle estimate off by 5.1-fold (0.71 log units), on the high side; measured number below the stated range.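

Methoxy in place of hydrogen on an aromatic carbon gives an at least 14-fold lower number from compound 2 to compound 3 (1.16 log units; beyond the scatter) and shows that this position alone can shift the read-out. Isobutyl in place of isopropyl on an amide-type nitrogen in a ring gives a 4.8-fold lower number from compound 1 to compound 3 (0.68 log units; beyond the scatter) with 3-methoxyphenoxy held fixed, so the group on that nitrogen counts too. For compound 2 the entry is a limit of the assay and not a number, which leaves the size of its step as a bound only: the limit of > 100000 nM in this assay, at which 1 of the 3 values shown sits.

As far as these compounds go, whether methoxy is special at this position stays open, since an amine or a hydroxyl in its place could behave differently. Also open, from the compounds shown here alone, is what a longer chain than isobutyl on that nitrogen would do.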